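A Chlorine Swap on the Weakest Compound

The source may hold more compounds than are shown below. What is called first, only, known or untested is meant among the compounds shown, and "the series" means these compounds.

Compound 1 `CC(C)(C)c1ccc(OCCCON2C(N)=NC(N)=NC23CCSCC3)cc1`: 280 nM
Compound 2 `COc1ccc(OCCCON2C(N)=NC(N)=NC23CCOCC3)cc1`: 1670 nM
Compound 3 `NC1=NC2(CCSCC2)N(OCCCOc2cccc(Cl)c2)C(N)=N1`: 260 nM

These values come from a functional assay on HL-60 cells (Homo sapiens) for antiproliferative activity, read by MTT assay, with a stated time of 72 h; a higher number here means a weaker inhibitor, a lower number a stronger inhibitor. Compound 2 has the highest number of the three, and compound 1 and compound 3 both lie lower, beyond the scatter. Compound 4 `NC1=NC2(CCOCC2)N(OCCCOc2ccccc2Cl)C(N)=N1` is unmeasured and has 2-chlorophenyl in place of 4-methoxyphenyl on an oxygen on a saturated carbon. Within the data shown here, no measured pair isolates this change. Compound 3 also bears a chlorophenyl group but has a different core, and it gives 260 nM, so a moderate fall in the number is expected in this assay. The expected step is a 2.2-fold lower number from compound 2 to compound 4 (0.35 log units; beyond the scatter). For compound 4 the estimated value is 750 nM, within an expected range of 250 nM to 2200 nM.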

Compound 4, half-maximal inhibitory concentration: 660 nM
Compound 4: the middle estimate sits 1.1-fold (0.06 log units) above what was measured, and the stated range covers the measured number.
By their numbers in this assay, from the lowest: compounds 3 and 1 (each within the scatter of the next); then compound 4; then compound 2.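

With the shared core held fixed, putting 2-chlorophenyl in place of 4-methoxyphenyl in this assay gives a 2.5-fold lower number from compound 2 to compound 4 (0.40 log units; beyond the scatter), a modest step. The earlier compounds shown here differed in more than one place, so none of them could isolate this change. Nothing measured here explains why the number falls. Still open, from the compounds shown here alone, is whether an amine or a carboxylic acid on the phenyl ring would shift the number further. Going by these compounds, it is also open whether the same swap would give a similar step on the core of compound 1.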